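This account rests on a few compounds, and the source may have more. Where it says the series, first, only, none or still open, it means among the compounds named here.

In a functional assay on MCF7 cells (Homo sapiens) for inhibition, read by MTT assay, with a stated time of 24 h (on this read-out higher numbers stand for weaker inhibition and lower numbers for stronger inhibition), three compounds have been run. Compound 1 `O=C(O)C1=Cc2ccccc2OC1(OCc1cc(-c2ccc([N+](=O)[O-])cc2)no1)C(F)(F)F` reaches only a limit of the assay, > 150000 nM. Compound 3 `CCOC(=O)C1=Cc2ccccc2OC1(OCc1cc(-c2ccc(C)cc2)no1)C(F)(F)F` likewise gives only a limit, > 150000 nM. Among the compounds with values here, compound 2 `CCOC(=O)C1=Cc2ccccc2OC1(OCc1cn(-c2ccc(F)c([N+](=O)[O-])c2)nn1)C(F)(F)F` is the sole compound with a number, 16200 nM. The other two stand at the limit of > 150000 nM in this assay, at which 2 of the 3 values shown sit. Compound 4 `CCOC(=O)C1=Cc2ccccc2OC1(OCc1cn(-c2ccc([N+](=O)[O-])cc2)nn1)C(F)(F)F` has not yet been measured in this assay. It differs from compound 2 in one place: 4-nitrophenyl in place of 4-fluoro-3-nitrophenyl on an aromatic nitrogen. Within the data shown here, no step between measured compounds is available, so the size of this change cannot be read from the data. The step of a 1.5-fold higher number from compound 2 to compound 4 (0.19 log units; within the scatter) is expected to lie within the usual scatter or a little toward weaker inhibition. Compound 4 is estimated at 25000 nM, between 8000 nM and 100000 nM.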

Compound 4, half-maximal inhibitory concentration: > 150000 nM
Compound 4 ended at the assay's limit; the forecaster's own chance of this, stated with the estimate: 20%; middle value at least 6.0-fold (0.77 log units) away from the limit.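

The earlier compounds shown here gave no step at this position, and the result now supplies one: in this assay, 4-nitrophenyl in place of 4-fluoro-3-nitrophenyl on the aromatic nitrogen gives an at least 9.2-fold higher number from compound 2 to compound 4 (0.96 log units; beyond the scatter). The group on this nitrogen therefore matters, even though the two groups differ only in their substituents on the phenyl ring. Compound 4 gives only a limit of the assay, so the full size of the step stays unknown, and compound 2 remains the only compound with a number: the limit of > 150000 nM in this assay, at which 3 of the 4 values shown sit.

The compounds shown leave open whether the fluoro substituent or the placing of the nitro group carries the step. As far as these compounds go, how an amine or a methoxy group on that phenyl ring would read also remains open.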